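From 4-methylphenyl to 3-methylphenyl on a carbonyl carbon

The source may report more compounds than this note shows. Statements on the series, on what has been measured and on what is new or still open speak of the compounds shown alone.

Measured so far in an ADME assay on L929 cells (Mus musculus) for cytotoxicity, read by resazurin assay, with a stated time of 72 h; on this read-out higher numbers stand for weaker inhibition and lower numbers for stronger inhibition

Compound 1 `CC(=O)c1ccn(-c2ccc3c(c2)B(O)OC3)c1` gives > 10 ug/mL as a limit
Compound 2 `O=C(c1ccn(-c2ccc3c(c2)B(O)OC3)c1)c1ccccc1Cl` gives > 10 ug/mL as a limit
Compound 3 `Cc1ccc(C(=O)c2ccn(-c3ccc4c(c3)B(O)OC4)c2)cc1` gives > 10 ug/mL as a limit

Compound 3 stands at > 10 ug/mL in this assay as a limit and not a number. For the measured compounds named here, the series so far shows the limit of > 10 ug/mL in this assay, at which 3 of the 3 values shown sit, and nothing finer. Compound 4 `Cc1cccc(C(=O)c2ccn(-c3ccc4c(c3)B(O)OC4)c2)c1` has 3-methylphenyl in place of 4-methylphenyl on a carbonyl carbon with the same atoms joined differently. Going by the values given here, the steps that bear on this change are a step that the two limits leave unreadable from compound 1 to compound 3 and a step that the two limits leave unreadable from compound 2 to compound 3 and neither offers a size to carry over. No step beyond the scatter is therefore expected in this assay and no direction can be named. The estimated step is a step that the limit leaves unreadable from compound 3 to compound 4 for this change. For compound 4 the estimated value is 20 ug/mL with a range from 10 ug/mL to 50 ug/mL and a report as a limit is expected.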

Compound 4, half-maximal inhibitory concentration: > 10 ug/mL
Compound 4 was reported as a limit (the forecaster's own chance of this, stated with the estimate: 85%); the middle value lies beyond the limit too.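

In this assay compound 4 gives > 10 ug/mL, a limit and not a number. No step can be read from compound 1, compound 2 or compound 3 to compound 4. The compounds shown leave open how the groups on the carbonyl carbon compare.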